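Methoxy in place of hydrogen: compound 1 to compound 3

The source may hold more compounds than are shown below. What is called first, only, known or untested is meant among the compounds shown, and "the series" means these compounds.

Going by the values given here, compound 1 `O=C1/C(=C/c2ccccc2)CCC/C1=C\c1cccc([N+](=O)[O-])c1` is the only member of the series with a number in a functional assay on MOLT-4 cells (Homo sapiens) for cytotoxicity, with a stated time of 72 h; on this read-out higher numbers stand for weaker inhibition and lower numbers for stronger inhibition. In this assay compound 1 gives 1700 nM. Compound 2 `CN(C)c1ccc(/C=C2\CCC/C(=C\c3ccc([N+](=O)[O-])cc3)C2=O)cc1` is reported in this assay only as a limit of the assay, > 500000 nM. Among the compounds with values here, compound 2 differs from compound 1 in more than one place, so the pair shows no single step; the two values show only that one is a number and the other a limit, as noted under (the limit of > 500000 nM in this assay, at which 1 of the 2 values shown sits). Compound 3 `COc1ccc(/C=C2\CCC/C(=C\c3cccc([N+](=O)[O-])c3)C2=O)cc1` is not yet measured. It differs from compound 1 by methoxy in place of hydrogen on an aromatic carbon, para to a large group. Within the data shown here, no step between two measured compounds carrying this same change exists, so the size of the step is open. The expectation is a modest loss in this assay, a 2.4-fold higher number from compound 1 to compound 3 (0.37 log units; beyond the scatter), a step that may or may not exceed the scatter. For compound 3 the estimate in this assay is 4000 nM, expected to fall between 1000 nM and 25000 nM.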

Compound 3, half-maximal inhibitory concentration in the MOLT-4 assay: 7980 nM
Compound 3: the middle estimate sits 2.0-fold (0.30 log units) below what was measured; the measured number falls inside the stated range.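

Methoxy in place of hydrogen gives the series its first single-place step. In the MOLT-4 assay compound 1 gives 1700 nM and compound 3 gives 7980 nM. In the MOLT-4 assay the step is a 4.7-fold higher number from compound 1 to compound 3 (0.67 log units; beyond the scatter). The change from phenyl to 4-methoxyphenyl, on an aromatic carbon para to a large group, therefore gives a modest loss and leaves a measurable number, so this position tolerates a group of 2 heavy atoms with a hydrogen-bond acceptor, at least for this one example. In a physicochemical assay for lipophilicity (a higher number here means a more lipophilic compound, a lower number a more polar compound), compound 1 gives 5.06 and compound 3 gives 5.06. In the physicochemical assay the same change gives no change at the digits printed from compound 1 to compound 3 (within the scatter), so the loss in the MOLT-4 assay has no matching step on the partition scale, and nothing else shown accounts for it.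

One step cannot show whether the loss is specific to methoxy or would recur with other groups on the same carbon, such as hydroxy, fluorine, ethoxy or a carboxylic acid. Going by these compounds alone, it also remains open whether methoxy would give a step of similar size on a core with the nitro group placed differently, since no second pair carrying this change is available for comparison.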